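The compounds below may be only part of what the source reports. "The series", "measured", "known", "first", "only" and "open" are said of these compounds alone.

- Compound 1 `Cc1cnc(NC(=O)c2cc(Oc3ccc(S(C)(=O)=O)cc3)c3cc(C)oc3c2)cn1`: 13 mL/min/kg
- Compound 2 `Cc1cc2c(Oc3cnc(C(=O)N4CC(C)C4)cn3)cc(C(=O)Nc3cnccn3)cc2o1`: < 9.6 mL/min/kg
- Compound 3 `Cc1cc2c(Oc3cnc(C(=O)N4CC(C)(O)C4)cn3)cc(C(=O)Nc3cnccn3)cc2o1`: not yet measured

In an ADME assay (liver) for metabolic stability, with Liver microsome (Homo sapiens) as the target, using microsomes (a higher number here means faster removal of the compound, a lower number slower removal), compound 2 gives < 9.6 mL/min/kg, which is a limit of the assay and not a number. Compound 1 gives an actual number, 13 mL/min/kg, but no exact gap to compound 2 can be read from these results.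

Compound 3 differs from compound 2 in one place: hydroxy in place of hydrogen on a saturated ring carbon. A hydroxy group takes the place of a hydrogen on a saturated ring carbon, turning 3-methylazetidin-1-yl into 3-hydroxy-3-methylazetidin-1-yl.

Within the data shown here, no measured pair of compounds shows what this change does, so the expected step, a step that the limit leaves unreadable from compound 2 to compound 3, is none beyond the scatter, in either direction. A further limit result would not be surprising. For compound 3 the estimated clearance is 8 mL/min/kg, with an expected range of 4.5 mL/min/kg to 13 mL/min/kg.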

Compound 3, clearance: < 8 mL/min/kg
Compound 3 gave a limit, no number; the forecaster's own chance of this, stated with the estimate: 65%; the middle value lies on the limit itself.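

In this assay, among these compounds, compound 2 and compound 3 both give limits of the assay rather than numbers, so no step between them can be read. The compounds shown leave open what swapping hydrogen for hydroxy on the saturated ring carbon does to clearance.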